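Aryl variation on the shared selenium-containing core

The source may report more compounds than this note shows. Statements on the series, on what has been measured and on what is new or still open speak of the compounds shown alone.

Measured so far in a functional assay on A549 cells (Homo sapiens) for antiproliferative activity, read by CCK-8 assay, with a stated time of 48 h; a lower number here means a stronger inhibitor, a higher number a weaker inhibitor:
compound 1 `Cc1ccc(-c2nnc(-n3[se]c4ccccc4c3=O)s2)cc1` — 13400 nM
compound 2 `O=c1c2ccccc2[se]n1-c1nnc(-c2cccc([N+](=O)[O-])c2)s1` — 16100 nM

Compound 1 has the lowest of the two numbers, but compound 2 lies within the scatter of it, so no order between the two can be read from these values. Both carry the shared core and differ only in the aryl group attached to it.

Compound 3 `O=c1c2ccccc2[se]n1-c1nnc(-c2ccccc2Br)s1` has not yet been measured. It differs from compound 1 in one place: 2-bromophenyl in place of 4-methylphenyl on an aromatic carbon. Among the compounds with values here, no step between measured compounds covers a change of this kind. The two aryl variants measured so far sit close together, which gives no ground to expect the bromine-bearing ring to move the number beyond the scatter in either direction.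

Compound 3 is therefore expected to give about 13000 nM, within a range from 5500 nM to 32000 nM. The expected step of a 1.0-fold lower number from compound 1 to compound 3 (0.01 log units; within the scatter) stays within the scatter.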

Compound 3, half-maximal inhibitory concentration: 12700 nM
Estimate against measurement, compound 3: 1.0-fold (0.01 log units) above; the range from low to high includes it.
By their numbers in this assay, from the lowest: compounds 3, 1 and 2 (each within the scatter of the next).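

Within the data shown here, the exchange of 4-methylphenyl for 2-bromophenyl on this aromatic carbon gives a 1.1-fold lower number from compound 1 to compound 3 (0.02 log units; within the scatter) in this assay, the first step that can be read at this position. On this evidence, the aryl group can carry a bromine in place of a methyl, at a different place on the phenyl ring, without the two compounds separating. The step alters the substituent and its place together, so it cannot show what either alteration would do alone, and no measurement at hand bears on the reason for this result.

As far as these compounds go, all three compounds keep a substituted phenyl ring at this position, so it remains open whether an amine, a carboxylic acid or a longer alkyl chain there would separate from compound 1. From the compounds shown here alone, the shared core is the same throughout, and the effect of altering it also remains open.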